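Amino to Hydroxy on the Saturated Ring: Expected Stability

The source may hold more compounds than are shown below. What is called first, only, known or untested is meant among the compounds shown, and "the series" means these compounds.

Compound 1 `NC1CCC(CN2CCN(c3cc(=O)c4cc(C(F)(F)F)cc([N+](=O)[O-])c4s3)CC2)CC1` is the reference of this small series. In an ADME assay on cells (Hepatocyte, Homo sapiens) for metabolic stability, with a stated time of 30 min (a lower number here means that less of the compound is left, a higher number that more of the compound is left), compound 1 gives 83.6%, the highest of the three numbers measured. Its two neighbours carry ester groups where compound 1 carries an amino group: compound 2 `O=C(OC1CCC(CN2CCN(c3cc(=O)c4cc(C(F)(F)F)cc([N+](=O)[O-])c4s3)CC2)CC1)C1CCCCC1` gives 2.8% in this assay, and compound 3 `O=C(OC1CCC(CN2CCN(c3cc(=O)c4cc(C(F)(F)F)cc([N+](=O)[O-])c4s3)CC2)CC1)c1ccco1` gives 1%. Both steps away from compound 1 are large: a number 80.8 percentage points lower from compound 1 to compound 2 (beyond the scatter) and a number 82.6 percentage points lower from compound 1 to compound 3 (beyond the scatter). Between the two esters the difference is small, a number 1.8 percentage points lower from compound 2 to compound 3 (within the scatter).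

Compound 4 `O=c1cc(N2CCN(CC3CCC(O)CC3)CC2)sc2c([N+](=O)[O-])cc(C(F)(F)F)cc12` differs from compound 1 in one place: hydroxy in place of amino on a saturated ring carbon. For the measured compounds named here, the two measured steps from compound 1 replace the amino group with a (cyclohexylcarbonyl)oxy or a ((furan-2-yl)carbonyl)oxy group, not with a hydroxy group, so neither bears directly on this step; they show only that the amino group of compound 1 can be exchanged at this position with very different outcomes. Going by the values given here, no measured compound carries a hydroxy group on the saturated ring. The estimate for compound 4 in this assay is therefore set nearer to compound 1 than to the esters, with a wide range: 60% (25% to 90%), which means an expected step of a number 23.6 percentage points lower from compound 1 to compound 4 (beyond the scatter).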

Compound 4, percent of the compound remaining in the Hepatocyte assay: 72.7%
Estimate against measurement, compound 4: 12.7 percentage points below; the range from low to high includes it.
By their numbers in the Hepatocyte assay, from the lowest: compounds 3 and 2 (each within the scatter of the next); then compound 4; then compound 1.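

On the saturated ring carbon, hydroxy in place of amino costs little in the Hepatocyte assay, with a number 10.9 percentage points lower from compound 1 to compound 4 (beyond the scatter), so a high number at this position does not depend on the nitrogen of the amino group. The hydroxy compound also separates the oxygen itself from what is attached to it, with a number 71.7 percentage points higher from compound 3 to compound 4 (beyond the scatter) and a number 69.9 percentage points higher from compound 2 to compound 4 (beyond the scatter); the low numbers therefore go with the cyclohexylcarbonyl and (furan-2-yl)carbonyl groups on that oxygen, not with an oxygen at this position. The same change is less favourable on another read-out: in a physicochemical assay for solubility, read by HPLC, with a stated time of 20 min (on this read-out higher numbers stand for higher solubility and lower numbers for lower solubility), compound 1 gives 43.9 ug/mL and compound 4 gives 8.3 ug/mL, a modest step beyond the scatter.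

The compounds shown do not tell whether a methoxy group, an acetamide or a carboxylic acid on this ring carbon would keep the high number in the Hepatocyte assay while also giving a higher number in the physicochemical assay. They also leave open whether compound 2 and compound 3 are cleaved to compound 4 in the cells or are lost by some other route.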